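Fluoro Added Beside Fluoro on Pyrrolidine Urea

The source may report more compounds than this note shows. Statements on the series, on what has been measured and on what is new or still open speak of the compounds shown alone.

In an ADME assay on HepG2 cells (Homo sapiens) for inhibition, read by resazurin assay, with a stated time of 48 h (on this read-out lower numbers stand for an effect already at smaller amounts and higher numbers for an effect only at larger amounts of compound), compound 1 `O=C(Nc1ccc2sc(-c3cccc(F)c3)nc2c1)N1CCCCC1` gives only a limit, > 50 uM. Compound 2 `O=C(Nc1ccc2sc(-c3ccc(F)c(F)c3)nc2c1)N1CCCCC1` likewise gives a limit in this assay, > 50 uM. Compound 3 `O=C(Nc1ccc2sc(-c3cccc(F)c3)nc2c1)N1CCCC1` also gives a limit in this assay, > 50 uM. The change from compound 1 to compound 2 is fluoro in place of hydrogen on an aromatic carbon, and its step is a step that the two limits leave unreadable from compound 1 to compound 2. The two cores differ by pyrrolidin-1-yl in place of piperidin-1-yl on a carbonyl carbon, with the step that the two limits leave unreadable from compound 1 to compound 3. Compound 4 `O=C(Nc1ccc2sc(-c3cccc(F)c3F)nc2c1)N1CCCC1` differs from compound 3 by fluoro in place of hydrogen on an aromatic carbon; the fluoro enters ortho to a large group here, where in compound 2 it entered para to a large group, so the change is the same kind of change, not the same. Given (the limit of > 50 uM in this assay, at which 3 of the 3 values shown sit), the step from compound 3 to compound 4 is expected to be a step that the limit leaves unreadable from compound 3 to compound 4. Compound 4 is expected to give about 60 uM in this assay, between 30 uM and 150 uM.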

Compound 4, concentration for 90% of the maximal effect: > 50 uM
Compound 4 ended at the assay's limit; the forecaster's own chance of this, stated with the estimate: 80%; the middle value lies beyond the limit too.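

In this assay, for the compounds shown here, compound 3 and compound 4 both give only a limit, so no step between them can be read. The compounds shown leave open how any fluoro or ring change acts, as every value sits at one limit: the limit of > 50 uM in this assay, at which 4 of the 4 values shown sit.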